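A few compounds are considered here, and "the series" means these few. Any claim that something is new, unique, unknown or untested is made for them only; others in the source may bear on it.

Working notes on the series. Of the compounds shown here, three sharing one core have been measured, differing only in the aryl group on the carbon with a double bond to nitrogen. In a functional assay on PC-3 cells (Homo sapiens) for inhibition (on this read-out higher numbers stand for weaker inhibition and lower numbers for stronger inhibition), compound 1 `Cc1c(C(=O)N/N=C\c2cc(O)ccc2O)oc2cccc(O)c12` gives 95500 nM. In this assay compound 2 `Cc1c(C(=O)N/N=C\c2ccccc2)oc2cccc(O)c12` gives 29200 nM. In this assay compound 3 `Cc1c(C(=O)N/N=C\c2cc(F)ccc2O)oc2cccc(O)c12` gives 3170 nM, the lowest number of the three; the steps of a 9.2-fold lower number from compound 2 to compound 3 (0.96 log units; beyond the scatter) and a 30-fold lower number from compound 1 to compound 3 (1.48 log units; beyond the scatter) both lie beyond the scatter, so compound 3 stands apart as the strongest inhibitor measured so far.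

Compound 4 `COc1cccc(/C=N\NC(=O)c2oc3cccc(O)c3c2C)c1` is not yet measured. The change from compound 3 is 3-methoxyphenyl in place of 5-fluoro-2-hydroxyphenyl on a carbon with a double bond to nitrogen. Among the measured compounds shown here, two measured steps bear on it. The step of a 9.2-fold lower number from compound 2 to compound 3 (0.96 log units; beyond the scatter) shows that introducing the 5-fluoro-2-hydroxyphenyl in place of phenyl lowered the number; compound 4 gives that group up again. The step of a 3.3-fold lower number from compound 1 to compound 2 (0.51 log units; beyond the scatter) shows that a phenyl without hydroxy groups gave a lower number than the 2,5-dihydroxyphenyl. For the measured compounds named here, no measured compound carries a 3-methoxyphenyl, so its own contribution is unknown. The expectation for compound 4 is therefore a modest step upward in this assay, back toward the value of compound 2, estimated as a 4.7-fold higher number from compound 3 to compound 4 (0.68 log units; beyond the scatter). The estimate for compound 4 in this assay is 15000 nM, with a range from 3000 nM to 60000 nM.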

Compound 4, half-maximal inhibitory concentration: >= 40000 nM
Compound 4: no number, only a limit (the forecaster's own chance of this, stated with the estimate: 10%); at least 2.6-fold (0.42 log units) between middle value and limit.
By their numbers in this assay, from the lowest: compound 3; then compound 2; then compound 1.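

The value for compound 4 in this assay is a limit and not a number: the limit of >= 40000 nM in this assay, at which 1 of the 4 values shown sits.

Even so, the position on the carbon with a double bond to nitrogen proves sensitive to this change: 3-methoxyphenyl in place of 5-fluoro-2-hydroxyphenyl gives an at least 12-fold higher number from compound 3 to compound 4 (1.10 log units; beyond the scatter), so a phenyl carrying methoxy does not retain the low number of compound 3. Against the unsubstituted phenyl the reading is far less firm, with an at least 1.3-fold higher number from compound 2 to compound 4 (0.13 log units; that floor lies within the scatter), so methoxy in place of hydrogen on the aromatic carbon cannot be given a direction, and the step involving compound 1 cannot be read.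

The compounds shown leave open whether the fluoro, the hydroxy or the two together account for the low number of compound 3, as the series holds no phenyl with a single fluoro or a single hydroxy to separate them. Also open, on these data alone, is how an amine or a carboxylic acid on this phenyl, or a longer chain such as ethoxy in place of methoxy, would read in this assay.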